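The source may hold more compounds than are shown below. What is called first, only, known or untested is meant among the compounds shown, and "the series" means these compounds.

Working notes on the series. Compound 3 `Cc1cc(C)c(NC(=O)N(Cc2ccc(-c3ccnn3C)cc2)C2CCCCCC2)c(C)c1` carries a 1-methyl-1H-pyrazol-5-yl on an aromatic carbon. In a functional assay on a cell-free system (plasma) with sterol O-acyltransferase, Soat (Rattus norvegicus) as the target (on this read-out lower numbers stand for an effect already at smaller amounts and higher numbers for an effect only at larger amounts of compound), compound 3 gives only a limit, < 1 mg/kg. Compound 1 `Cc1cc(C)c(NC(=O)N(Cc2ccc(N3CCN(C)CC3)cc2)C2CCCCCC2)c(C)c1` bears a 4-methylpiperazin-1-yl on that aromatic carbon. In this assay compound 1 also gives only a limit, > 1 mg/kg. Compound 2 `Cc1cc(C)c(NC(=O)N(Cc2ccc(-c3cc[nH]n3)cc2)C2CCCCCC2)c(C)c1` carries a 1H-pyrazol-3-yl there. For compound 2 this assay likewise returns only a limit, > 1 mg/kg. The steps are read from these limits alone: a number no higher from compound 1 to compound 3 (the limit leaves the size open) and a number no higher from compound 2 to compound 3 (the limit leaves the size open), while a step that the two limits leave unreadable from compound 1 to compound 2. Compound 3 sits at the limit of < 1 mg/kg in this assay, at which 1 of the 3 values shown sits, and the other two at the limit of > 1 mg/kg in this assay, at which 2 of the 3 values shown sit; no number is fixed for any of the three.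

Compound 4 `Cc1cc(C)c(NC(=O)N(Cc2ccc(-n3cncn3)cc2)C2CCCCCC2)c(C)c1` changes the group on that aromatic carbon: 1H-1,2,4-triazol-1-yl in place of 1-methyl-1H-pyrazol-5-yl on an aromatic carbon. Among the compounds with values here, no measured step covers a five-membered ring joined through a nitrogen; the two steps ending at compound 3 are of unreadable size, and the step between compound 1 and compound 2 is unreadable as well. The expectation for compound 4 can therefore only be set near the limit value, with a wide range, and the step of a number no lower from compound 3 to compound 4 (the limit leaves the size open) is estimated to stay within the scatter. Compound 4 is expected to give 1 mg/kg in this assay, between 0.3 mg/kg and 3 mg/kg.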

Compound 4, dose for half-maximal effect: > 1 mg/kg
Compound 4: a limit, no number; the forecaster's own chance of this, stated with the estimate: 60%; the middle value sits exactly at the limit.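

In this assay, 1H-1,2,4-triazol-1-yl in place of 1-methyl-1H-pyrazol-5-yl on an aromatic carbon para to a large group gives a number no lower from compound 3 to compound 4 (the limit leaves the size open). Of the five-membered aromatic rings at this position, only the 1-methyl-1H-pyrazol-5-yl of compound 3 stands on the lower side of the limit, while the 1H-pyrazol-3-yl of compound 2 and now the nitrogen-linked 1H-1,2,4-triazol-1-yl of compound 4 stand on the upper side: the limit of > 1 mg/kg in this assay, at which 3 of the 4 values shown sit. The steps to compound 4 from compound 1 and from compound 2 cannot be read, so no order can be given among these three compounds.

All four values are limits, so the size of any step at this position stays open, and the compounds shown do not separate the methyl on the ring of compound 3 from the way that ring is joined to the core. Also open, from the compounds shown here alone, is what a carboxylic acid or an aminomethyl group on this aromatic carbon would give in this assay.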